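Thioether chain shape and tolerance on human T-cell line

The source may report more compounds than this note shows. Statements on the series, on what has been measured and on what is new or still open speak of the compounds shown alone.

Compound 1, `Cc1c(Cc2c(F)cccc2Cl)nc(SC(C)C)[nH]c1=O`: in an ADME assay on MT4 cells (Homo sapiens) for activation, read by MTT assay (a higher number here means that more compound is tolerated, a lower number that less compound is tolerated), compound 1 gives > 76000 nM, which is a limit of the assay.
Compound 2, `CCCSc1nc(Cc2c(F)cccc2Cl)c(C)c(=O)[nH]1`: in this assay compound 2 gives > 76000 nM, again a limit.
Compound 3, `CC(C)Sc1nc(C(C)c2c(F)cccc2Cl)cc(=O)[nH]1`: in this assay compound 3 gives > 75000 nM, also a limit.

Compound 2 differs from compound 1 by propyl in place of isopropyl on a sulfur. Because both values sit at the limit of > 76000 nM in this assay, at which 2 of the 3 values shown sit, the step that the two limits leave unreadable from compound 1 to compound 2 cannot be read. Compound 4, `CCCSc1nc(C(C)c2c(F)cccc2Cl)cc(=O)[nH]1`, is not yet measured; it differs from compound 3 by propyl in place of isopropyl on a sulfur, the same change at the same place. The difference between the core of compound 1 and that of compound 3 is not broken down here. Since compound 3 sits at the limit of > 75000 nM in this assay, at which 1 of the 3 values shown sits, and the same change left compound 1 and compound 2 at their limits, compound 4 is expected to show a step that the limit leaves unreadable from compound 3 to compound 4. Compound 4 is therefore estimated at 80000 nM, most likely reported only as a limit.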

Compound 4, half-maximal cytotoxic concentration: > 75000 nM
Compound 4 was reported as a limit; the forecaster's own chance of this, stated with the estimate: 85%; the middle value does not contradict the limit.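

In this assay compound 4 gives > 75000 nM, which is a limit. For the compounds shown here, compound 3 also sits at a limit, so no step between compound 3 and compound 4 can be read. The compounds shown leave open whether propyl and isopropyl on the sulfur differ at all in tolerated concentration.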